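Branching the propyl chain on the shared core

The source may hold more compounds than are shown below. What is called first, only, known or untested is meant among the compounds shown, and "the series" means these compounds.

Measured compounds:
compound 1 `CCCn1cnc2ncnc(N)c21` — in an assay on CHO cells for displacement of a labelled ligand from adenosine receptor A3 (Homo sapiens) (on this read-out lower numbers stand for stronger inhibition and higher numbers for weaker inhibition), compound 1 gives > 100000 nM
compound 2 `CC(C)n1cnc2ncnc(N)c21` — compound 2 gives > 100000 nM
compound 3 `CC(C)Cn1cnc2c(N)ncnc21` — compound 3 gives > 100000 nM

Compound 1 stands only at a limit of this assay, not at a number. The step that the two limits leave unreadable from compound 1 to compound 2 is therefore unreadable. Compound 3 also rests at a limit, and all three values sit together, (the limit of > 100000 nM in this assay, at which 3 of the 3 values shown sit). Compound 4 `CC(C)Cn1cnc2ncnc(N)c21` differs from compound 1 by methyl in place of hydrogen on a saturated chain carbon bound to two saturated chain carbons. Among the measured compounds shown here, the one measured step, from compound 1 to compound 2, alters the same chain and shows nothing readable beyond two limits, so no move away from the limit is expected for compound 4. In this assay the expected step is a step that the limit leaves unreadable from compound 1 to compound 4. Compound 4 is estimated at 150000 nM, range 40000 nM to 600000 nM, most probably again only a limit.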

Compound 4, inhibition constant: > 100000 nM
Compound 4: only a limit was reported; the forecaster's own chance of this, stated with the estimate: 85%; the middle value does not contradict the limit.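

In this assay compound 4 gives > 100000 nM and this is only a limit; the steps to compound 4 from compound 1 and compound 2 cannot be read. The compounds shown leave open whether any chain on the shared core gives a measurable value.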